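Swapping a methyl for a cyano on the shared core

A few compounds are considered here, and "the series" means these few. Any claim that something is new, unique, unknown or untested is made for them only; others in the source may bear on it.

Compound 1, `Cc1ccc(-c2cs/c(=N/NC(=O)CSc3nnnn3-c3ccccc3)n2-c2ccccc2)cc1`, was tested in a functional assay on C6 cells (Rattus norvegicus) for cytotoxicity, read by MTT assay, with a stated time of 24 h (a higher number here means a weaker inhibitor, a lower number a stronger inhibitor), where compound 1 gives 14.7 ug/mL. Among the measured compounds shown here, its only measured companion is compound 2, `Cc1ccc(-c2cs/c(=N/NC(=O)CSc3nnnn3C)n2-c2ccccc2)cc1`, which in this assay gives 36.3 ug/mL. For the measured compounds named here, the one change between them is a methyl in place of a phenyl on an aromatic nitrogen, and it brought a 2.5-fold higher number from compound 1 to compound 2 (0.39 log units; beyond the scatter). Going by the values given here, of the two numbers known, compound 1 therefore has the lowest.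

Compound 3 is `N#Cc1ccc(-c2cs/c(=N/NC(=O)CSc3nnnn3-c3ccccc3)n2-c2ccccc2)cc1`. Set against compound 1, the difference is cyano in place of methyl on an aromatic carbon. Among the compounds with values here, the single measured step concerns a group on an aromatic nitrogen elsewhere in the core, so it does not speak to a change on the six-membered carbon ring; no measured pair shows a methyl giving way to a cyano. With nothing to point either way, the expectation for compound 3 in this assay is a step no larger than the scatter, a 1.2-fold higher number from compound 1 to compound 3 (0.06 log units; within the scatter), in no settled direction. Compound 3 is thus estimated at 17 ug/mL, with a range from 7 ug/mL to 40 ug/mL.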

Compound 3, half-maximal inhibitory concentration: > 200 ug/mL
Compound 3: only a limit was reported; the forecaster's own chance of this, stated with the estimate: 5%; middle value at least 11-fold (1.07 log units) from the limit.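

In this assay, the move from 4-methylphenyl to 4-cyanophenyl brings an at least 13-fold higher number from compound 1 to compound 3 (1.13 log units; beyond the scatter), whereas the earlier change on the aromatic nitrogen brought only a 2.5-fold higher number from compound 1 to compound 2 (0.39 log units; beyond the scatter). The entry for compound 3 is a limit of the assay and not a number: the limit of > 200 ug/mL in this assay, at which 1 of the 3 values shown sits. The earlier pair said nothing about the six-membered aromatic ring of carbon only, and this step shows that the group on that ring, para to a large group, is far from a silent detail, since one swap of methyl for cyano moves the result further than the phenyl-to-methyl change on the aromatic nitrogen did.

With only methyl and cyano shown at this place, it remains open whether the jump belongs to cyano in particular or would follow from replacing methyl with almost anything, a question that a chlorine atom, a methoxy group, an amine or a carboxylic acid at the same spot could begin to answer. From the compounds shown here alone, it is also open whether cyano would have a similar effect on the core of compound 2, which carries methyl rather than phenyl on the aromatic nitrogen.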